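This account rests on a few compounds, and the source may have more. Where it says the series, first, only, none or still open, it means among the compounds named here.

Working notes on the series. Compound 1 (`C[C@H](Nc1ncnc2[nH]cnc12)c1nn(-c2cccnc2)c2cc(Cl)ccc12`) gives > 40000 nM in a functional assay on HepG2 cells (Homo sapiens) for inhibition, read by sulforhodamine B assay, with a stated time of 72 h (a lower number here means a stronger inhibitor, a higher number a weaker inhibitor), and that is a limit of the assay, not a number. Among the measured compounds shown here, compound 2 (`C[C@H](Nc1ncnc2[nH]cnc12)c1nn(-c2cccnc2)c2cc(F)ccc12`) gives 37500 nM in this assay as the only true number so far, so it has no measured neighbour to be ranked against. For the measured compounds named here, the one measured step (an at least 1.0-fold lower number from compound 1 to compound 2 (0.02 log units; that floor lies within the scatter)) is fluoro in place of chloro on an aromatic carbon. It lies within the scatter and sits at another place in the structure than the change now in view.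

Compound 3 (`CC[C@H](Nc1ncnc2[nH]cnc12)c1nn(-c2cccnc2)c2cc(F)ccc12`) carries methyl in place of hydrogen on a saturated chain carbon, two bonds along the chain from an aromatic carbon and a nitrogen on an aromatic ring, which reads as methyl to ethyl. Going by the values given here, no measured step covers this change, so the expectation rests on compound 2 at 37500 nM and no shift beyond the scatter is expected in this assay. The expected step is a 1.2-fold lower number from compound 2 to compound 3 (0.07 log units; within the scatter) and it stays small. Given the limit of > 40000 nM in this assay, at which 1 of the 2 values shown sits, as the reference, compound 3 may also return only a limit. Compound 3 is estimated at 32000 nM with 15000 nM to 40000 nM as the expected range.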

Compound 3, half-maximal inhibitory concentration: 33900 nM
Compound 3: middle estimate off by 1.1-fold (0.03 log units), on the low side; low and high end bracket the measured number.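

In this assay, methyl in place of hydrogen on a saturated chain carbon, two bonds along the chain from an aromatic carbon and a nitrogen on an aromatic ring, gives a 1.1-fold lower number from compound 2 to compound 3 (0.04 log units; within the scatter). Among the compounds shown here, this is the first measured step at this position, since the earlier step, fluoro in place of chloro on an aromatic carbon, lay at another place in the structure, and it shows that methyl to ethyl leaves compound 3 within the scatter of compound 2, with no order between the two. Compound 1 remains a limit and not a number: the limit of > 40000 nM in this assay, at which 1 of the 3 values shown sits.

As far as these compounds go, one step at this position sets no trend, and it remains open whether a longer chain such as propyl, or an amine or a carboxylic acid carried on that chain, would move the number beyond the scatter. Also open, from the compounds shown here alone, is whether a change elsewhere on the shared core, for example a methoxy group in place of the fluoro, would give a number clearly removed from compound 2.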